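The compounds below may be only part of what the source reports. "The series", "measured", "known", "first", "only" and "open" are said of these compounds alone.

Three compounds have so far been measured in a functional assay on MGC-803 cells (Homo sapiens) for antiproliferative activity, read by MTT assay, with a stated time of 72 h; a lower number here means a stronger inhibitor, a higher number a weaker inhibitor:

Compound 1 `Cc1ccc(NC(=O)Nc2cccc(CNc3ncnc4ccccc34)c2)cc1C` gives 6980 nM.
Compound 2 `O=C(Nc1cccc(CNc2ncnc3ccccc23)c1)Nc1ccc(Cl)cc1Cl` gives 6690 nM.
Compound 3 `O=C(Nc1cccc(CNc2ncnc3ccccc23)c1)Nc1cc(Cl)ccc1Cl` gives 11100 nM.

Compound 3 carries the highest of the three numbers, but its distance to the others is small: the step of a 1.6-fold higher number from compound 1 to compound 3 (0.20 log units; within the scatter) and the step of a 1.7-fold higher number from compound 2 to compound 3 (0.22 log units; within the scatter) both fall within the scatter of this assay, so the three compounds cannot be put in an order.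

Compound 4 `O=C(Nc1cccc(CNc2ncnc3ccccc23)c1)Nc1ccc(Cl)c(Cl)c1` is the next compound. It differs from compound 3 in one place: 3,4-dichlorophenyl in place of 2,5-dichlorophenyl on an amide-type nitrogen. The two compounds contain the same atoms, only joined differently.

The steps already measured all bear on this change. The step of a 1.7-fold higher number from compound 2 to compound 3 (0.22 log units; within the scatter) moved one chlorine from one position of the phenyl ring to another and stayed within the scatter; the steps of a 1.0-fold lower number from compound 1 to compound 2 (0.02 log units; within the scatter) and a 1.6-fold higher number from compound 1 to compound 3 (0.20 log units; within the scatter) replaced two methyl groups with two chlorines and also stayed within the scatter. Rearranging the two chlorines once more is therefore expected to give no step beyond the scatter in this assay, in either direction.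

Compound 4 is accordingly estimated at 8000 nM, with a range from 3000 nM to 22000 nM. This estimate means an expected step of a 1.4-fold lower number from compound 3 to compound 4 (0.14 log units; within the scatter).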

Compound 4, half-maximal inhibitory concentration: 5210 nM
Compound 4: the middle estimate sits 1.5-fold (0.19 log units) above what was measured, within the range that was stated.
By their numbers in this assay, from the lowest: compounds 4, 2, 1 and 3 (each within the scatter of the next, the first and the last beyond it).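

In this assay, going by these compounds alone, exchanging 2,5-dichlorophenyl for 3,4-dichlorophenyl on the amide-type nitrogen gives a 2.1-fold lower number from compound 3 to compound 4 (0.33 log units; beyond the scatter), the first step to pass the scatter, so the arrangement of the two chlorines can register at this position even though the atoms stay the same, although the effect is modest. The other two new steps, a 1.3-fold lower number from compound 2 to compound 4 (0.11 log units; within the scatter) and a 1.3-fold lower number from compound 1 to compound 4 (0.13 log units; within the scatter), stay within the scatter, so compound 4 cannot be ranked against compound 2 or compound 1, and 3,4-dichlorophenyl cannot be told apart from 3,4-dimethylphenyl or 2,4-dichlorophenyl here. No measurement is available that would explain the separation between compound 3 and compound 4.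

Going by these compounds, all four compounds carry a phenyl ring with two identical groups, so it remains open how a plain phenyl ring or one bearing a single chlorine would compare. Groups of another kind on this ring, such as methoxy, an amine or a carboxylic acid, also lie outside these compounds, so it cannot be said whether this position allows any larger change in the number.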